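The source may hold more compounds than are shown below. What is called first, only, known or untested is meant among the compounds shown, and "the series" means these compounds.

Working notes on the series. Compound 1 `COc1cc2c(Oc3ccc(NC(=O)C4(c5nnc(-c6ccc(F)cc6)o5)CC4)cc3F)ccnc2cc1OCCCN1CCN(C)CC1` carries an amide linked through a three-membered carbocycle to the fluorophenyl-bearing oxadiazole and a 3-(4-methylpiperazin-1-yl)propyl ether on the shared core. In a functional assay on HT-29 cells (Homo sapiens) for antiproliferative activity, read by MTT assay, with a stated time of 72 h (a lower number here means a stronger inhibitor, a higher number a weaker inhibitor), compound 1 gives 1050 nM. Within the data shown here, the two other compounds measured so far are compound 2 `COc1cc2nccc(Oc3ccc(NC(=O)c4nnc(-c5ccc(F)cc5)o4)cc3)c2cc1OC`, with a directly attached oxadiazole amide and plain methoxy ethers, and compound 3 `COc1cc2c(Oc3ccc(NC(=O)c4cc(-c5ccc(F)cc5)on4)cc3)ccnc2cc1OCCCN1CCC(C)CC1`, with an isoxazole amide and a 3-(4-methylpiperidin-1-yl)propyl ether. In this assay compound 2 gives 52300 nM. In this assay compound 3 gives 24600 nM. Compound 1 thus shows the lowest number of the three, with compound 3 nearest and compound 2 furthest, both gaps beyond the scatter. These pairs differ in more than one place, so nothing can be said of any single change among them.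

Compound 4 `COc1cc2c(Oc3ccc(NC(=O)C4(c5nnc(-c6ccc(F)cc6)o5)CC4)cc3F)ccnc2cc1OCCCN1CCCCC1` keeps everything of compound 1 except the terminal amine of the propyl ether: piperidin-1-yl in place of 4-methylpiperazin-1-yl on a saturated chain carbon, three bonds along the chain from an oxygen on an aromatic ring. Among the measured compounds shown here, no measured pair isolates this change. The expected step of a 1.1-fold higher number from compound 1 to compound 4 (0.06 log units; within the scatter) is none beyond the scatter, since the rest of the molecule is unchanged. Compound 4 is therefore estimated at 1200 nM, in the range 400 nM to 4000 nM.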

Compound 4, half-maximal inhibitory concentration: 1030 nM
Estimate against measurement, compound 4: 1.2-fold (0.07 log units) above; the range from low to high includes it.
By their numbers in this assay, from the lowest: compounds 4 and 1 (each within the scatter of the next); then compound 3; then compound 2.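

Among these compounds, the step of a 1.0-fold lower number from compound 1 to compound 4 (0.01 log units; within the scatter) in this assay is the first reading of a single change: piperidin-1-yl in place of 4-methylpiperazin-1-yl on a saturated chain carbon, three bonds along the chain from an oxygen on an aromatic ring, stays within the scatter. With the amide, the three-membered carbocycle, the oxadiazole and the shared core held fixed, going from a terminal ring with 2 hetero atoms to one with 1 hetero atom, and losing the methyl group with it, leaves the number unmoved beyond the scatter, so on this background the terminal position accepts either ring. No measurement in hand accounts for this result.

Going by these compounds, whether a morpholin-4-yl ring, an open dimethylamino group, a carboxylic acid or a longer chain at this position would also stay within the scatter remains open. Also open, on these data alone, is whether the two rings read alike on other amide backgrounds, such as the isoxazole amide of compound 3 or the directly attached oxadiazole amide of compound 2.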